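Replacing Methylphenyl with Fluorophenyl at the Ring Nitrogen

A few compounds are considered here, and "the series" means these few. Any claim that something is new, unique, unknown or untested is made for them only; others in the source may bear on it.

compound 1 `COc1ccc(S(=O)(=O)Nc2ccc(-c3cc(N)n(-c4ccccc4)n3)cc2)cc1`: 100 nM
compound 2 `COc1ccc(S(=O)(=O)Nc2ccc(-c3cc(N)n(-c4cccc(C)c4)n3)cc2)cc1`: 37 nM
compound 3 `COc1ccc(S(=O)(=O)Nc2ccc(-c3cc(N)n(-c4cc(C(F)(F)F)cc(C(F)(F)F)c4)n3)cc2)cc1`: > 1000 nM

In an assay on HEK293 cells for binding affinity to Neuropeptide Y receptor type 5 (Homo sapiens), read by radioligand binding (a higher number here means a weaker inhibitor, a lower number a stronger inhibitor), compound 2 stands at the lowest of the two numbers recorded, with compound 1 as its nearest neighbour, a 2.7-fold lower number from compound 1 to compound 2 (0.43 log units; beyond the scatter). The value of compound 3 is a limit of this assay rather than a number, as described by the limit of > 1000 nM in this assay, at which 1 of the 3 values shown sits. Compound 4 `COc1ccc(S(=O)(=O)Nc2ccc(-c3cc(N)n(-c4ccc(F)cc4)n3)cc2)cc1` carries 4-fluorophenyl in place of 3-methylphenyl on an aromatic nitrogen. Going by the values given here, the only measured step that bears on this change is a 2.7-fold lower number from compound 1 to compound 2 (0.43 log units; beyond the scatter), which shows what a methyl on that ring adds; compound 4 gives the methyl up and takes a fluorine instead, for which no measured step exists. The expected step is therefore a modest rise, a 2.2-fold higher number from compound 2 to compound 4 (0.33 log units; beyond the scatter). Compound 4 is estimated in this assay at 80 nM, ranging from 30 nM to 250 nM.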

Compound 4, half-maximal inhibitory concentration: 37 nM
Compound 4: middle estimate off by 2.2-fold (0.33 log units), on the high side; the measured number falls inside the stated range.
By their numbers in this assay, from the lowest: compounds 2 and 4 (each within the scatter of the next); then compound 1. At a limit, above all of these: compound 3.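

In this assay, 4-fluorophenyl on the aromatic nitrogen matches 3-methylphenyl, with no change at the digits printed from compound 2 to compound 4 (within the scatter). A fluorine on the phenyl ring gives a 2.7-fold lower number from compound 1 to compound 4 (0.43 log units; beyond the scatter), so the gain over the unsubstituted phenyl of compound 1 is not tied to a methyl group. Nothing shown gives a cause for this match. From the compounds shown here alone, whether a methoxy group, a nitrile or an amine on this phenyl ring would hold the number at this level stays open. So does the effect of a cyclohexyl group in place of the phenyl ring.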